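The compounds below may be only part of what the source reports. "The series", "measured", "known", "first", "only" and "open" are said of these compounds alone.

Series in an ADME assay on BJ cells (Homo sapiens) for cytotoxicity, with a stated time of 72 h; on this read-out lower numbers stand for an effect already at smaller amounts and higher numbers for an effect only at larger amounts of compound:
Compound 1 `Cc1cc(NC(=O)Nc2ccccc2OC(F)(F)F)c2ccccc2n1`: > 25000 nM, a limit of the assay
Compound 2 `Cc1cc(NC(=O)Nc2ccccc2C(C)(C)C)c2ccccc2n1`: 22000 nM

Within the data shown here, compound 2 holds the only actual number, as the other value is a limit. Compound 3 `CSc1ccccc1NC(=O)Nc1cc(C)nc2ccccc12` differs from compound 2 by methylsulfanyl in place of tert-butyl on an aromatic carbon, with methylsulfanyl in place of tert-butyl on an aromatic carbon. Among the measured compounds shown here, the one measured step at this place is an at least 1.1-fold lower number from compound 1 to compound 2 (0.05 log units; that floor lies within the scatter). Compound 1 stands at the limit of > 25000 nM in this assay, at which 1 of the 2 values shown sits. That step gives no size, so no step beyond the scatter is expected in this assay. The expected change is a 1.0-fold higher number from compound 2 to compound 3 (0.02 log units; within the scatter). For compound 3 the estimate is 23000 nM, with an expected range of 13000 nM to 40000 nM.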

Compound 3, half-maximal effective concentration: > 25000 nM
Compound 3 gave a limit, no number; the forecaster's own chance of this, stated with the estimate: 50%; middle value at least 1.0-fold (0.03 log units) from the limit.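

Methylsulfanyl in place of tert-butyl on an aromatic carbon, ortho to a large group, gives an at least 1.1-fold higher number from compound 2 to compound 3 (0.05 log units; that floor lies within the scatter) in this assay. The step between compound 1 and compound 3 cannot be read, as both values are limits. Limits now make up most of the series: the limit of > 25000 nM in this assay, at which 2 of the 3 values shown sit.

The compounds shown leave open whether an amine or a carboxylic acid at this place would give a readable number clearly apart from that of compound 2.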